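Side-chain changes on a shared quinone core with aziridines

A few compounds are considered here, and "the series" means these few. Any claim that something is new, unique, unknown or untested is made for them only; others in the source may bear on it.

The series starts from compound 1 `COCCC1=C(N2CC2)C(=O)C(C)=C(N2CC2)C1=O`, which in a functional assay on L1210 cells (Mus musculus), with a stated time of 1 days (on this read-out higher numbers stand for higher potency (the scale is a negative logarithm) and lower numbers for lower potency), gives 5.19. Compound 2 `CC1=C(N2CC2)C(=O)C(CCC(=O)N(C)C)=C(N2CC2)C1=O` differs from it in one place: in this assay compound 2 gives 5.09. Between the two there is a number 0.10 log units lower from compound 1 to compound 2 (within the scatter), so compound 2 stands at the lowest of the two numbers seen so far, and its nearest neighbour, compound 1, sits within the scatter of it.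

Compound 3 `CC1=C(N2CC2)C(=O)C(COc2ccccc2)=C(N2CC2)C1=O` has not been measured. It differs from compound 2 as follows: phenoxy in place of (dimethylcarbamoyl)methyl on a saturated chain carbon bound to a double-bonded ring carbon. Among the compounds with values here, the only measured step that bears on this change is the one from compound 1 to compound 2, which swapped one chain substituent for another on the same side chain and produced a difference within the scatter. On that basis the step to compound 3 is expected to be small, with no direction resolved beyond the scatter; the estimated step is a number 0.16 log units higher from compound 2 to compound 3 (within the scatter). Compound 3 is therefore expected to give about 5.25 in this assay, with a range from 4.75 to 5.75.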

Compound 3, logarithm of the reciprocal of the active concentration, log(1/C): 4.68
Compound 3: middle estimate off by 0.57 log units, on the high side; measured number below the stated range.
By their numbers in this assay, from the lowest: compound 3; then compounds 2 and 1 (each within the scatter of the next).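

In this assay, within the data shown here, this place on the chain no longer looks indifferent to what it carries: phenoxy in place of (dimethylcarbamoyl)methyl gives a number 0.41 log units lower from compound 2 to compound 3 (beyond the scatter), and phenoxy in place of methoxymethyl gives a number 0.51 log units lower from compound 1 to compound 3 (beyond the scatter), whereas the one earlier step, a number 0.10 log units lower from compound 1 to compound 2 (within the scatter), did not separate the two compounds. Of the three groups compared here, phenoxy alone brings a six-membered aromatic ring of carbon only, and among these three compounds the lower number goes with that ring, while methoxymethyl and (dimethylcarbamoyl)methyl remain within the scatter of each other. Nothing available explains the lower number of compound 3.

The compounds shown leave open whether the aromatic ring itself or its attachment through oxygen goes with the lower number, a question that a benzyl group or a phenylthio group at the same place could help to separate. They also leave open whether a dimethylamino group, a carboxylic acid or a longer chain at this place would stay level with compound 1 and compound 2 or fall with compound 3.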